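Swapping Chlorine for Fluorine: What Compound 3 Might Give

The source may report more compounds than this note shows. Statements on the series, on what has been measured and on what is new or still open speak of the compounds shown alone.

compound 1 `COc1cc(-c2cc(/C=C/C(=O)c3ccc(Cl)c(Cl)c3)[nH]n2)cc(OC)c1OC`: 89%
compound 2 `COc1ccc(-c2cc(/C=C/C(=O)c3cc(OC)c(OC)c(OC)c3)[nH]n2)cc1OC`: 67%

In a functional assay on MDA-MB-231 cells (Homo sapiens) for cytotoxicity, read by sulforhodamine B assay, with a stated time of 48 h, tested at 1 uM (a lower number here means a stronger effect, a higher number a weaker effect of the compound at the concentration tested), compound 1 stands highest of the two numbers, meaning the weaker effect; compound 2 lies lower by a gap beyond the usual scatter. Compound 3 `COc1cc(-c2cc(/C=C/C(=O)c3ccc(F)c(F)c3)[nH]n2)cc(OC)c1OC` differs from compound 1 in one place: 3,4-difluorophenyl in place of 3,4-dichlorophenyl on a carbonyl carbon. Going by the values given here, no measured pair shows this exact change, so its size is unknown. In this assay a small step is expected, quite possibly none beyond the scatter, with a slight lean toward a higher number. Compound 3 is therefore estimated at 88%, within 70% to 100%. The expected step is a number 1 percentage points lower from compound 1 to compound 3 (within the scatter).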

Compound 3, a percentage reported as activity, at one concentration (the size of the read-out at that concentration, not a potency): 74%
Compound 3: middle estimate off by 14 percentage points, on the high side; the measured number falls inside the stated range.
By their numbers in this assay, from the lowest: compounds 2 and 3 (each within the scatter of the next); then compound 1.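

In this assay the change from 3,4-dichlorophenyl to 3,4-difluorophenyl on the carbonyl carbon gives a number 15 percentage points lower from compound 1 to compound 3 (beyond the scatter) and thus a stronger effect at the concentration tested. Going by these compounds alone, this is the first comparison of compounds that differ in one place, and it shows that exchanging one halogen pair for another here can alone shift the read-out. Nothing available explains this step.

Still open, going by these compounds, is how an unsubstituted phenyl, or a phenyl carrying an amine or a carboxylic acid, would behave at this carbonyl carbon. It is also unclear whether the same swap would give a similar step on the core of compound 2.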